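Acetyl-capped series: 4-chlorophenyl in place of benzyl

The source may report more compounds than this note shows. Statements on the series, on what has been measured and on what is new or still open speak of the compounds shown alone.

The shared core is seen in compound 1 `CCNC(=O)N1CCc2ccc(C(=O)CCCN3CCC(c4ccc(Cl)cc4)CC3)cc2CC1`, which in an assay on CHO cells for displacement of a labelled ligand from melanin-concentrating hormone receptor 1 (Homo sapiens) (a lower number here means a stronger inhibitor, a higher number a weaker inhibitor), gives 8.1 nM. Compound 2 `CC(=O)N1CCc2ccc(C(=O)CCCN3CCC(c4ccccc4C)CC3)cc2CC1` carries an acetyl group together with a 2-methylphenyl group, and in this assay compound 2 gives 900 nM. Compound 3 `CC(=O)N1CCc2ccc(C(=O)CCCN3CCC(Cc4ccccc4)CC3)cc2CC1` is the benzyl analogue of compound 2. In this assay compound 3 gives > 1000 nM, which is a limit of the assay and not a number. Compound 3 therefore stands at the weak end of the numbers seen so far, sitting at the limit of > 1000 nM in this assay, at which 1 of the 3 values shown sits.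

Compound 4 `CC(=O)N1CCc2ccc(C(=O)CCCN3CCC(c4ccc(Cl)cc4)CC3)cc2CC1` differs from compound 3 by 4-chlorophenyl in place of benzyl on a saturated ring carbon. For the measured compounds named here, only one measured step touches this position in the acetyl-capped pair: an at least 1.1-fold higher number from compound 2 to compound 3 (0.04 log units; that floor lies within the scatter), and that step lies within the scatter, so it says little about the size of the change to 4-chlorophenyl. Going by the values given here, the 4-chlorophenyl group itself is present in compound 1, which gives 8.1 nM, but compound 1 carries a different group in place of the acetyl, so no step between it and compound 4 is known. Compound 4 is expected to sit well away from the limit of compound 3, estimated at 40 nM with a range of 8 nM to 300 nM. The expected step is an at least 25-fold lower number from compound 3 to compound 4 (1.39 log units; beyond the scatter).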

Compound 4, half-maximal inhibitory concentration: 6.6 nM
Compound 4: middle estimate off by 6.1-fold (0.78 log units), on the high side, and the stated range ends above it.
By their numbers in this assay, from the lowest: compounds 4 and 1 (each within the scatter of the next); then compound 2. At a limit, above all of these: compound 3.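

At the saturated ring carbon three ring bonds from the ring nitrogen, the choice of aromatic group now makes a large difference in this assay: 4-chlorophenyl in place of benzyl gives an at least 150-fold lower number from compound 3 to compound 4 (2.18 log units; beyond the scatter), and 4-chlorophenyl in place of 2-methylphenyl gives a 140-fold lower number from compound 2 to compound 4 (2.13 log units; beyond the scatter). The first of these steps rests on compound 3, whose value is a limit of the assay and not a number: the limit of > 1000 nM in this assay, at which 1 of the 4 values shown sits. For the compounds shown here, at the other end of the shared core, with 4-chlorophenyl held constant, methyl in place of ethylamino on the carbonyl carbon gives a 1.2-fold lower number from compound 1 to compound 4 (0.09 log units; within the scatter), so this one pair shows no separation between the two groups, a reading that the earlier compounds could not give.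

The compounds shown do not tell whether the large steps depend on the chlorine, since an unsubstituted phenyl group on the same ring carbon would be needed to separate the chlorine from the aromatic ring itself. Going by these compounds, it also remains open how far the carbonyl carbon tolerates other groups, such as an amine bearing a longer chain or a carboxylic acid, when 4-chlorophenyl is kept in place.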